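Pyrrolidinone for methylpiperazine: tolerance in HEL cells

The compounds below may be only part of what the source reports. "The series", "measured", "known", "first", "only" and "open" are said of these compounds alone.

Compound 1 `Cc1cc(N2CCN(C)CC2)cn2c(CSCCc3ccccc3)cnc12` in an ADME assay on HEL cells (Homo sapiens) for cytotoxicity, with a stated time of 3 days (a lower number here means that less compound is tolerated, a higher number that more compound is tolerated), gives 20 ug/mL. Compound 2 `Cc1cc(N2CCCC2=O)cn2c(CSCCc3ccccc3)cnc12` gives only a limit in this assay, > 100 ug/mL. The change 2-oxopyrrolidin-1-yl in place of 4-methylpiperazin-1-yl on an aromatic carbon thus produces an at least 5.0-fold higher number from compound 1 to compound 2 (0.69 log units; beyond the scatter). Compound 3 `Cc1cc(N2CCN(C)CC2)c2ncc(CSCCc3ccccc3)n2c1` has the same atoms as compound 1 joined differently; the difference between the two cores is not broken down here, and in this assay compound 3 stands at "not determined" (no result reported). Compound 4 `Cc1cc(N2CCCC2=O)c2ncc(CSCCc3ccccc3)n2c1` is not yet measured. It carries the same kind of change, (2-oxopyrrolidin-1-yl in place of 4-methylpiperazin-1-yl on an aromatic carbon), though the place is now ortho to a fused ring and meta to a fused ring rather than meta and para to a fused ring. Compound 4 is expected to reach 100 ug/mL, between 30 ug/mL and 200 ug/mL, because the earlier step from compound 1 to compound 2 sat at the limit of > 100 ug/mL in this assay, at which 1 of the 3 values shown sits.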

Compound 4, minimum cytotoxic concentration: 20 ug/mL
For compound 4 the middle estimate is 5.0-fold (0.70 log units) above the measured one, and the stated range ends above it.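

In this assay, within the data shown here, compound 3 stands at "not determined" (no result reported) and compound 4 gives 20 ug/mL, and no step between them can be read. The compounds shown leave open what 2-oxopyrrolidin-1-yl in place of 4-methylpiperazin-1-yl does on the core of compound 3.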